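Replacing the 2,4-dioxo-1,3-thiazolidin-5-yl Group of Compound 2

The source may report more compounds than this note shows. Statements on the series, on what has been measured and on what is new or still open speak of the compounds shown alone.

In a physicochemical assay for solubility, measured as kinetic solubility, at pH 2 (on this read-out lower numbers stand for lower solubility and higher numbers for higher solubility), compound 1 (`CC(C)C(c1ccc(-c2ccc3cccc(F)c3c2)[nH]c1=O)C1NC(=O)NC1=O`) gives 5800 nM and compound 2 (`CC(C)C(c1ccc(-c2ccc3cccc(F)c3c2)[nH]c1=O)C1SC(=O)NC1=O`) gives 11300 nM. The two differ in one place, with 2,4-dioxo-1,3-thiazolidin-5-yl standing in place of 2,5-dioxoimidazolidin-4-yl. Within the data shown here, that step, a 1.9-fold higher number from compound 1 to compound 2 (0.29 log units; within the scatter), leaves compound 2 level with compound 1, the only other compound measured so far. Compound 3 (`CC(C)C(/C=C1\SC(=O)NC1=O)c1ccc(-c2ccc3cccc(F)c3c2)[nH]c1=O`) differs from compound 2 by a group of 8 heavy atoms (4 carbon, 1 nitrogen, 2 oxygen, 1 sulfur; one five-membered non-aromatic ring with 2 hetero atoms) in place of a group of 7 heavy atoms (3 carbon, 1 nitrogen, 2 oxygen, 1 sulfur; one five-membered non-aromatic ring with 2 hetero atoms), on a saturated chain carbon bound to an aromatic carbon and a saturated chain carbon. Among the measured compounds shown here, no measured step covers this exact change. The step to compound 2 is the only one that bears on it, and it exchanged a different group without moving this assay beyond the scatter. No step beyond the scatter is therefore expected here. The estimate amounts to a 1.4-fold lower number from compound 2 to compound 3 (0.15 log units; within the scatter), which is an expected step within the scatter. Compound 3 is expected at 8000 nM, with an estimated range of 3000 nM to 20000 nM.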

Compound 3, solubility: 4800 nM
Compound 3: the middle estimate sits 1.7-fold (0.22 log units) above what was measured, and the stated range covers the measured number.
By their numbers in this assay, from the lowest: compounds 3, 1 and 2 (each within the scatter of the next, the first and the last beyond it).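

Of the steps at this position, only one lies beyond the scatter in this assay, namely a 2.4-fold lower number from compound 2 to compound 3 (0.37 log units; beyond the scatter) when the entering group brings 8 heavy atoms and 3 double bonds outside aromatic rings in place of 7 heavy atoms and 2 such bonds, with the counts of hydrogen-bond donors and acceptors unchanged. The same group set against the 2,5-dioxoimidazolidin-4-yl group gives a 1.2-fold lower number from compound 1 to compound 3 (0.08 log units; within the scatter) and so leaves compound 3 level with compound 1 despite the different ring.

Compound 3 gains a carbon and a double bond together, and the compounds shown do not separate the two. They also leave open how this assay would respond to an amine, a carboxylic acid or a longer chain on this saturated chain carbon. No measurement offered here accounts for the step from the 2,4-dioxo-1,3-thiazolidin-5-yl group.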